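The source may hold more compounds than are shown below. What is called first, only, known or untested is meant among the compounds shown, and "the series" means these compounds.

Compound 1 `CCOc1ccccc1-c1ccc(-c2nc3cnccc3c(N[C@H](CC)C(=O)N(C)C)c2C#N)cc1` is the more lipophilic of the two measured compounds. In a physicochemical assay for lipophilicity, read by HPLC, at pH 7.5 (on this read-out higher numbers stand for higher lipophilicity and lower numbers for lower lipophilicity), compound 1 gives 3.7, while compound 2 `CC[C@@H](Nc1c(C#N)c(-c2ccc(-c3cccc(Cl)c3F)cc2)nc2cnccc12)C(=O)O` gives 2.2, a gap beyond the usual scatter. Compound 3 `CCOc1ccccc1-c1ccc(-c2nc3cnccc3c(NC(COC)C(N)=O)c2C#N)cc1` has not yet been measured and differs from compound 1 in one place: 1-carbamoyl-2-methoxyethyl in place of 1-(dimethylcarbamoyl)propyl on a nitrogen on an aromatic ring. Among the compounds with values here, no measured pair shows this exact change, so the size of the step is uncertain. A clear fall in this assay is nonetheless expected, a step of about a number 1.40 log units lower from compound 1 to compound 3 (beyond the scatter). Compound 3 is therefore estimated at 2.3, with a likely range from 1.8 to 2.8.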

Compound 3, distribution coefficient: 2.8
For compound 3 the middle estimate is 0.50 log units below the measured one, and the stated range covers the measured number.
By their numbers in this assay, from the lowest: compound 2; then compound 3; then compound 1.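

In this assay, the group on this nitrogen on an aromatic ring clearly moves the read-out: with the shared core unchanged, 1-carbamoyl-2-methoxyethyl in place of 1-(dimethylcarbamoyl)propyl gives a number 0.90 log units lower from compound 1 to compound 3 (beyond the scatter) as the first step seen at this position. The entering group also brings a hydrogen-bond donor that the leaving group lacks. No measurement here explains the size of this step.

Several edits travel together in this one change, so their separate shares remain open. A 1-carbamoylpropyl group would isolate the amide change from the methoxy, and an amine on the chain would test a different kind of group.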